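The compounds below may be only part of what the source reports. "The series", "measured", "known", "first", "only" and "open" are said of these compounds alone.

In a physicochemical assay for solubility, read by HPLC, in phosphate buffer, with a stated time of 20 h, at pH 7.4 (on this read-out lower numbers stand for lower solubility and higher numbers for higher solubility), compound 1 `O=C(O)C[C@H]1CC[C@H](c2ccc(C(=O)Nc3noc(Cc4ccccc4)n3)cc2)CC1` gives 129000 nM. Compound 2 `NC(=O)C[C@H]1CC[C@H](c2ccc(C(=O)Nc3nnc(Cc4ccccc4)s3)cc2)CC1` gives < 2000 nM, which is a limit and not a number. Compound 3 `CC(C)(O)CNC(=O)C[C@H]1CC[C@H](c2ccc(C(=O)Nc3nnc(Cc4ccccc4)s3)cc2)CC1` gives < 2000 nM, also a limit. Compound 3 therefore has no number of its own, and the series shows (the limit of < 2000 nM in this assay, at which 2 of the 3 values shown sit).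

Compound 4 `COCCNC(=O)C[C@H]1CC[C@H](c2ccc(C(=O)Nc3nnc(Cc4ccccc4)s3)cc2)CC1` is the next to be read, and its change from compound 3 is methoxymethyl in place of 1-hydroxy-1-methylethyl on a saturated chain carbon bound to an amide-type nitrogen. For the measured compounds named here, the only measured step bearing on this side chain is a step that the two limits leave unreadable from compound 2 to compound 3, so it offers no size and no direction. Going by the values given here, compound 1 differs from compound 3 in more than one place and gives no step here.

The expectation rests on compound 3, whose entry of < 2000 nM is a limit. No step beyond the scatter is expected in this assay, in either direction, and a reading at the same limit is the likely outcome. The estimated step is a step that the limit leaves unreadable from compound 3 to compound 4. For compound 4 the estimated value is 1200 nM, with an expected range of 300 nM to 4000 nM.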

Compound 4, solubility: < 2000 nM
Compound 4 ended at the assay's limit; the forecaster's own chance of this, stated with the estimate: 80%; the middle value does not contradict the limit.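

No new step can be read in this assay, since compound 2, compound 3 and compound 4 each give a limit and not a number: the limit of < 2000 nM in this assay, at which 3 of the 4 values shown sit.

As far as these compounds go, what stays open is how the solubility of these three compounds compares beneath that shared limit.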